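Adding One Chain Carbon to Compound 3

The source may report more compounds than this note shows. Statements on the series, on what has been measured and on what is new or still open speak of the compounds shown alone.

Compound 1 `Brc1cccc(OCCCCn2ccnc2)c1` gives 27600 nM
Compound 2 `Ic1ccc(OCCCCCn2ccnc2)cc1` gives 11000 nM
Compound 3 `c1ccc2sc(SCCCn3ccnc3)nc2c1` gives 27500 nM

In a functional assay on MCF7 cells (Homo sapiens) for cytotoxicity, read by sulforhodamine B assay, with a stated time of 72 h (a higher number here means a weaker inhibitor, a lower number a stronger inhibitor), compound 3 stands at 27500 nM, level with compound 1 within the usual scatter, while compound 2 shows a lower number, beyond the scatter. Compound 4 `c1ccc2sc(SCCCCn3ccnc3)nc2c1` carries (1H-imidazol-1-yl)methyl in place of 1H-imidazol-1-yl on a saturated chain carbon, three bonds along the chain from a sulfur. For the measured compounds named here, no measured pair isolates this change, so no step beyond the scatter is expected, with only a slight lean toward a lower number. The estimated change is a 1.3-fold lower number from compound 3 to compound 4 (0.12 log units; within the scatter). For compound 4 the expected value is 21000 nM, within an estimated range of 9000 nM to 45000 nM.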

Compound 4, half-maximal inhibitory concentration: 27500 nM
The estimate for compound 4 lay 1.3-fold (0.12 log units) below the measured number; the measured number falls inside the stated range.
By their numbers in this assay, from the lowest: compound 2; then compounds 3, 4 and 1 (each within the scatter of the next).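

For the compounds shown here, the first step that isolates one change shows that (1H-imidazol-1-yl)methyl in place of 1H-imidazol-1-yl, on a saturated chain carbon, three bonds along the chain from a sulfur, gives no change at the digits printed from compound 3 to compound 4 (within the scatter) in this assay on the shared core. At this position, then, the added chain carbon does not separate the two compounds. Nothing available explains this result. Still open, on these data alone, is whether a longer chain would leave the number equally unmoved, and whether an amine in place of 1H-imidazol-1-yl would shift it.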